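Cyano for methylsulfonyl: notes toward compound 3

A few compounds are considered here, and "the series" means these few. Any claim that something is new, unique, unknown or untested is made for them only; others in the source may bear on it.

Measured so far:
compound 1 `CS(=O)(=O)c1ccc(-c2cnc3[nH]cc(-c4nnc(-c5ccc(Cl)cc5)o4)c(=O)c3c2)cc1` — 2.15%
compound 2 `Cc1ccc(-c2nnc(-c3c[nH]c4ncc(-c5ccc(S(C)(=O)=O)cc5)cc4c3=O)o2)cc1` — 0.43%

Both measured compounds were run in a functional assay on KB cells (Homo sapiens) for inhibition, read by MTT assay, with a stated time of 24 h, tested at 5 uM; a higher number here means more inhibition of growth at the concentration tested, a lower number less inhibition of growth. Compound 1 gives 2.15% and compound 2 gives 0.43%. Among the measured compounds shown here, compound 1 holds the higher of the two numbers, but the single comparison available, a number 1.7 percentage points lower from compound 1 to compound 2 (within the scatter), lies within the scatter, so no order between the two can be claimed.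

Compound 3 `N#Cc1ccc(-c2cnc3[nH]cc(-c4nnc(-c5ccc(Cl)cc5)o4)c(=O)c3c2)cc1` is not yet measured. It differs from compound 1 in one place: cyano in place of methylsulfonyl on an aromatic carbon. For the measured compounds named here, the one measured step, methyl in place of chloro, sits on a different ring and amounted to a number 1.7 percentage points lower from compound 1 to compound 2 (within the scatter); it offers no direct guidance on an exchange at the methylsulfonyl position. What the numbers do show is that both measured compounds produce only slight growth inhibition in this assay, and nothing measured hints at a large movement in either direction. For compound 3 the expected step is therefore a number 0.9 percentage points higher from compound 1 to compound 3 (within the scatter), that is, no change beyond the scatter. Compound 3 is estimated at 3%, with a range from -8% to 15%.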

Compound 3, percent growth inhibition at one concentration: 7.35%
Compound 3: middle estimate off by 4.4 percentage points, on the low side; measured number inside the range.
By their numbers in this assay, from the lowest: compounds 2, 1 and 3 (each within the scatter of the next).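

Cyano in place of methylsulfonyl, the 4-(methylsulfonyl)phenyl to 4-cyanophenyl exchange, is the first measured change at this position, and in this assay it gives a number 5.2 percentage points higher from compound 1 to compound 3 (within the scatter). The position therefore accepts a swap from a group of 4 heavy atoms with 2 hydrogen-bond acceptors to one of 2 heavy atoms with 1 hydrogen-bond acceptor, with no step beyond the scatter, and the sulfur and both oxygens can go without a readable loss in this read-out; like the chloro to methyl exchange on the other aryl ring, this change leaves the series at low growth inhibition, with compound 3 at 7.35%. No measurement is available that bears on the origin of this small step.

Open, on these data alone, is whether an amine, a carboxylic acid or a longer alkyl chain on this aromatic carbon would produce a step beyond the scatter, or whether the position stays as flat with such groups as with cyano and methylsulfonyl. Also open, as far as these compounds go, is whether methyl in place of chloro behaves the same way on the 4-cyanophenyl compound as on the 4-(methylsulfonyl)phenyl pair.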